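The source may report more compounds than this note shows. Statements on the series, on what has been measured and on what is new or still open speak of the compounds shown alone.

Of the compounds shown here, three with a shared core have been measured in a functional assay for inhibition, with Homo sapiens as the target (on this read-out higher numbers stand for weaker inhibition and lower numbers for stronger inhibition), so far. Compound 1 `Fc1ccc(Nc2nccc(-c3ccncc3)n2)cc1` gives 1900 nM in this assay, the second highest of the three numbers. Its nearest neighbour is compound 3 `NS(=O)(=O)c1cccc(Nc2nccc(-c3ccncc3)n2)c1`, which gives 500 nM, a lower number that lies beyond the scatter. Furthest away is compound 2 `CCOC(=O)c1ccc(Nc2nccc(-c3cccnc3)n2)cc1`, which gives 12400 nM, a higher number that also lies beyond the scatter. No two of these compounds differ in one place alone, so no single step can be read from them directly.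

The next compound, compound 4 `CC(=O)Nc1ccc(Nc2nccc(-c3ccncc3)n2)cc1`, differs from compound 1 in one place: acetamido in place of fluoro on an aromatic carbon. Going by the values given here, the step from fluoro to acetamido puts a hydrogen-bond donor and a hydrogen-bond acceptor where none stood before, and the only measured compound carrying a donor, compound 3 with 500 nM, sits at the low end. On that basis the step of a 1.6-fold lower number from compound 1 to compound 4 (0.20 log units; within the scatter) is expected to be small, towards a lower number, and possibly within the scatter. Compound 4 is therefore estimated at 1200 nM, with a range from 300 nM to 5000 nM.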

Compound 4, half-maximal inhibitory concentration: 5300 nM
Compound 4: middle estimate off by 4.4-fold (0.65 log units), on the low side; measured number above the stated range.
By their numbers in this assay, from the lowest: compound 3; then compound 1; then compound 4; then compound 2.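

Measured in this assay the exchange of fluoro for acetamido gives a 2.8-fold higher number from compound 1 to compound 4 (0.45 log units; beyond the scatter) at this place, para to a large group. Going by these compounds alone, this is the first step that can be read at a single place, and it shows that the number responds to what stands on this aromatic carbon. It also shows that here a larger group carrying a hydrogen-bond donor and a hydrogen-bond acceptor goes with weaker inhibition, not stronger, and nothing at hand accounts for that rise.

One step cannot show whether the rise belongs to the whole acetamido group or to a part of it, and an amine at this place would help to separate the two. It also leaves open how a carboxylic acid or a methoxy group would fare on the same carbon, and whether either would fall nearer to fluoro or to acetamido.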